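Benzyl on the Ring Amide Nitrogen of Compound 2

The source may report more compounds than this note shows. Statements on the series, on what has been measured and on what is new or still open speak of the compounds shown alone.

Compound 1, `CCC1(CCCCN2CCN(c3ccc(OC)cc3)CC2)C(=O)Nc2ccccc21`: in a functional assay on the whole organism (strain Wistar) with Rattus norvegicus as the target, with a stated time of 5 min (a higher number here means that more compound is needed for the effect, a lower number that less compound is needed), compound 1 gives > 20 mg/kg, which is a limit of the assay and not a number.
Compound 2, `CCC1(CCCCN2CCN(c3ccccc3OC)CC2)C(=O)Nc2ccccc21`: in this assay compound 2 gives 10 mg/kg.

Compound 2 therefore holds the only number shown, the other value being a limit (the limit of > 20 mg/kg in this assay, at which 1 of the 2 values shown sits). For the measured compounds named here, the single measured step, an at least 2.0-fold lower number from compound 1 to compound 2 (0.30 log units; that floor lies within the scatter), concerns a different site. Compound 3, `CCC1(CCCCN2CCN(c3ccccc3OC)CC2)C(=O)N(Cc2ccccc2)c2ccccc21`, differs from compound 2 by benzyl in place of hydrogen on an amide-type nitrogen in a ring. Going by the values given here, no measured step bears on this change, so its direction is open. Compound 3 is expected to give 15 mg/kg, between 5 mg/kg and 40 mg/kg, the expected step being a 1.5-fold higher number from compound 2 to compound 3 (0.18 log units; within the scatter).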

Compound 3, minimum effective dose: > 20 mg/kg
Compound 3: only a limit was reported (the forecaster's own chance of this, stated with the estimate: 40%); middle value at least 1.3-fold (0.12 log units) from the limit.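

On the ring amide nitrogen, benzyl in place of hydrogen gives an at least 2.0-fold higher number from compound 2 to compound 3 (0.30 log units; that floor lies within the scatter) in this assay and is the first reading shown for this position. The reading for compound 3 is a limit and not a number. The step therefore has only a floor, and that floor does not separate the pair beyond the scatter: the limit of > 20 mg/kg in this assay, at which 2 of the 3 values shown sit.

On these data alone, it remains open whether methyl or a longer alkyl chain on this nitrogen would keep the value of compound 2, 10 mg/kg, in this assay. Also open, as far as these compounds go, is what an amine or carboxylic acid on such a chain would do.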